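The compounds below may be only part of what the source reports. "The series", "measured", "known", "first", "only" and "open" are said of these compounds alone.

Measured so far:
compound 1, `CCn1c(SCC(=O)Nc2ccc(/C(C)=N/O)cc2)nnc1-c1ccc(OC)cc1` — 65%
compound 2, `CCn1c(SCC(=O)Nc2ccc(C(C)=O)cc2)nnc1-c1ccc(OC)c(OC)c1` — 66%

In a functional assay on the whole organism (strain albino) for inhibition, with Rattus norvegicus as the target, read by paw edema, with stated times of 30 min and 5 h, at a dose of 0.28 mmol/kg by the oral route (a lower number here means less inhibition, a higher number more inhibition at the dose given (going by the name of the read-out)), compound 2 gives 66%. This is the larger of the two figures shown, but compound 1 gives 65%, and the gap between the two lies within the scatter, so neither can be set above the other. Going by the values given here, no pair of measured compounds differs in only one place, so no single step has been isolated here.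

Compound 3, `CCn1c(SCC(=O)Nc2ccc(C(C)=O)cc2)nnc1-c1ccc(OC)cc1`, has not been measured. It differs from compound 2 by hydrogen in place of methoxy on an aromatic carbon. Nothing measured speaks to this change directly, and the two numbers shown are so close that no trend can be drawn from them. The step from compound 2 to compound 3 is therefore expected to be small, a number 4 percentage points lower from compound 2 to compound 3 (within the scatter), not beyond the scatter in either direction. Compound 3 is estimated at 62%, within a range from 45% to 78%.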

Compound 3, a percentage reported as inhibition, in the whole organism at one dose (the size of the read-out at that dose, not a potency): 62%
For compound 3 middle estimate and measured number coincide at the digits printed; the measured number falls inside the stated range.
By their numbers in this assay, from the lowest: compounds 3, 1 and 2 (each within the scatter of the next).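

In this assay, the change from 3,4-dimethoxyphenyl to 4-methoxyphenyl gives a number 4 percentage points lower from compound 2 to compound 3 (within the scatter), so at this dose hydrogen in place of this methoxy, ortho to a methoxy group, makes no difference that can be told from the scatter. The other step, a group of 3 heavy atoms in place of a group of 4 heavy atoms on an aromatic carbon, gives a number 3 percentage points lower from compound 1 to compound 3 (within the scatter), so this second change cannot be told from the scatter either. Nothing is available to explain either step.

The compounds shown leave open whether an ethoxy group, a hydroxyl or an amine in place of this methoxy would move the number beyond the scatter, and whether hydrogen in place of the other methoxy would do so. They also leave open whether a carboxylic acid in place of the group of 3 heavy atoms would set a compound apart from compound 3.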